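Compound 3 and the cytotoxicity limit

The compounds below may be only part of what the source reports. "The series", "measured", "known", "first", "only" and "open" are said of these compounds alone.

Compound 1: > 20000 nM, a limit and not a number
Compound 2: > 20000 nM, a limit and not a number

Compound 1 `CC(C)N(c1cc(C#CC(C)(C)C)sc1C(=O)O)C(=O)[C@H]1CC[C@H](C)CC1` and compound 2 `CC(C)(C)C#Cc1cc(N(C(=O)[C@H]2CC[C@H](C)CC2)[C@H]2CC[C@H](Oc3nccs3)CC2)c(C(=O)O)s1` were both tested in an ADME assay on MT4 cells (Homo sapiens) for cytotoxicity, with a stated time of 5 days; a higher number here means that more compound is tolerated, a lower number that less compound is tolerated. Compound 2 `CC(C)(C)C#Cc1cc(N(C(=O)[C@H]2CC[C@H](C)CC2)[C@H]2CC[C@H](Oc3nccs3)CC2)c(C(=O)O)s1` gives only a limit in this assay, > 20000 nM. The whole data set so far is the limit of > 20000 nM in this assay, at which 2 of the 2 values shown sit, so no exact number is available as a starting point.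

Compound 3 `C[C@@H](CCOc1cccnc1)N(c1cc(C#CC(C)(C)C)sc1C(=O)O)C(=O)[C@H]1CC[C@H](C)CC1` carries a new group on the amide-type nitrogen, with 1-methyl-3-((pyridin-3-yl)oxy)propyl in place of 4-((1,3-thiazol-2-yl)oxy)cyclohexyl on an amide-type nitrogen.

One measured step changes this same nitrogen, and it is a step that the two limits leave unreadable from compound 1 to compound 2. It has no readable size, so it offers no measured effect to carry over. What it does show is that neither the isopropyl of compound 1 nor the group of compound 2 gave a reading short of the limit. No change beyond the usual scatter is therefore expected in this assay, and the direction is left open. The expected step is a number no higher from compound 2 to compound 3 (the limit leaves the size open). For compound 3 the estimated value is 20000 nM, with an expected range from 9000 nM to 40000 nM, and a report of only a limit is the likeliest outcome.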

Compound 3, half-maximal cytotoxic concentration: > 20000 nM
Compound 3 ended at the assay's limit; the forecaster's own chance of this, stated with the estimate: 75%; the middle value lies on the limit itself.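

Compound 3 returns only a limit in this assay, as compound 1 and compound 2 do, so no step among these three compounds can be read, and the results stand at one point: the limit of > 20000 nM in this assay, at which 3 of the 3 values shown sit. The compounds shown leave open how much of each the cells would tolerate, and whether the groups on the amide-type nitrogen differ in this at all.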